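The source may hold more compounds than are shown below. What is called first, only, known or untested is meant among the compounds shown, and "the series" means these compounds.

- Compound 1 `CC(C)[C@H](NC(=O)COc1cccc2ccccc12)C(=O)N[C@@H](CC(=O)O)C(=O)COc1ccc(C#N)cc1`: 26700 nM
- Compound 2 `CC(C)[C@H](NC(=O)COc1cccc2ccccc12)C(=O)N[C@@H](CC(=O)O)C(=O)COc1ccc(Oc2ccccc2)cc1`: 19000 nM
- Compound 3 `CC(C)[C@H](NC(=O)COc1cccc2ccccc12)C(=O)N[C@@H](CC(=O)O)C(=O)COc1ccccc1F`: 15700 nM

In a functional assay with Homo sapiens as the target (a higher number here means a weaker inhibitor, a lower number a stronger inhibitor), compound 3 gives 15700 nM, and all three values lie within the usual scatter of one another. Compound 4 `CC(C)[C@H](NC(=O)COc1cccc2ccccc12)C(=O)N[C@@H](CC(=O)O)C(=O)COc1ccc(F)cc1` carries 4-fluorophenyl in place of the 2-fluorophenyl of compound 3, on an oxygen on a saturated carbon (4-fluorophenyl in place of 2-fluorophenyl on an oxygen on a saturated carbon). Among the measured compounds shown here, two measured steps bear on this change. One is a 1.7-fold lower number from compound 1 to compound 3 (0.23 log units; within the scatter), which swaps this same group, and the other is a 1.4-fold lower number from compound 1 to compound 2 (0.15 log units; within the scatter), which alters a substituent on it. Both stayed within the scatter, so no real shift is expected from moving one fluorine. The expected change is a 1.1-fold higher number from compound 3 to compound 4 (0.06 log units; within the scatter), again within the scatter. For compound 4 the estimated value is 18000 nM, with an expected range from 10000 nM to 32000 nM.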

Compound 4, half-maximal inhibitory concentration: 14300 nM
Estimate against measurement, compound 4: 1.3-fold (0.10 log units) above; low and high end bracket the measured number.
By their numbers in this assay, from the lowest: compounds 4, 3, 2 and 1 (each within the scatter of the next).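

Moving the fluorine, with 4-fluorophenyl in place of 2-fluorophenyl on this oxygen, gives a 1.1-fold lower number from compound 3 to compound 4 (0.04 log units; within the scatter) in this assay, so where the fluorine sits on this ring makes no readable difference here. Fluoro in place of phenoxy gives a 1.3-fold lower number from compound 2 to compound 4 (0.12 log units; within the scatter) and fluoro in place of cyano gives a 1.9-fold lower number from compound 1 to compound 4 (0.27 log units; within the scatter), so all the ring substituents shown remain within the scatter of one another. No measurement available here accounts for these results. As far as these compounds go, whether an amine on this ring, or a longer saturated chain in place of the ring, would move the number beyond the scatter remains open.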